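The source may hold more compounds than are shown below. What is called first, only, known or untested is meant among the compounds shown, and "the series" means these compounds.

Three compounds with a shared core, differing only in the aryl group on one amide-type nitrogen, have been measured in an assay on isolated protein for inhibition of STE20-like serine/threonine-protein kinase (Homo sapiens), read by thermal shift assay, tested at 10 uM; a higher number here means that the compound stabilises the target more against heat, a lower number that the compound stabilises the target less. Compound 1 `Cc1ccc(F)cc1NC(=O)Nc1cc(C(C)(C)C)nn1-c1ccccc1` gives 6 degrees C. Compound 2 `Cc1ccc(NC(=O)Nc2cc(C(C)(C)C)nn2-c2ccccc2)cc1` gives 4.6 degrees C, and compound 3 `CC(C)(C)c1cc(NC(=O)Nc2cc(F)cc(F)c2)n(-c2ccccc2)n1` gives 3 degrees C, the lowest of the three numbers. The steps between them are all modest: a number 1.4 degrees C lower from compound 1 to compound 2 (beyond the scatter), a number 3.0 degrees C lower from compound 1 to compound 3 (beyond the scatter), and a number 1.6 degrees C lower from compound 2 to compound 3 (beyond the scatter).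

Compound 4 `CC(C)(C)c1cc(NC(=O)Nc2cc(F)cc(F)c2)n(C(C)(C)C)n1` changes a different part of compound 3: tert-butyl in place of phenyl on an aromatic nitrogen. Within the data shown here, none of the measured steps touches this position; all three concern the aryl group on the amide-type nitrogen, so they tell only that this assay does respond to modest changes around the shared core. Among the measured compounds shown here, with no measured step bearing directly on the change, the expectation rests on compound 3 alone, and a modest lowering or no step beyond the scatter seems most likely; the estimated step is a number 1.5 degrees C lower from compound 3 to compound 4 (beyond the scatter). Compound 4 is therefore expected to give about 1.5 degrees C, within a range from -0.5 degrees C to 3.5 degrees C.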

Compound 4, shift of the target's melting temperature: 0.2 degrees C
For compound 4 the middle estimate is 1.3 degrees C above the measured one; low and high end bracket the measured number.
By their numbers in this assay, from the lowest: compound 4; then compound 3; then compound 2; then compound 1.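

The group on the aromatic nitrogen matters in this assay, and not only the aryl group on the amide-type nitrogen: tert-butyl in place of phenyl gives a number 2.8 degrees C lower from compound 3 to compound 4 (beyond the scatter). This step is modest in size but beyond the scatter, and it leaves compound 4 with 0.2 degrees C, the lowest number of the four compounds. The change removes an aromatic ring and also lowers the heavy-atom count, so this single pair cannot separate those two differences, and no measurement at hand explains the drop.

Going by these compounds, it remains open how a small methyl group, a longer chain such as n-butyl, or a benzyl group would read at this aromatic nitrogen. On these data alone, it is also open whether tert-butyl there would lower the number equally with the 5-fluoro-2-methylphenyl group on the amide-type nitrogen.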